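Notes on the step from compound 1 to compound 4

The compounds below may be only part of what the source reports. "The series", "measured", "known", "first", "only" and "open" are said of these compounds alone.

Measured so far in a functional assay on MCF7 cells (Homo sapiens) for antiproliferative activity, read by CCK-8 assay, with a stated time of 48 h; a lower number here means a stronger inhibitor, a higher number a weaker inhibitor:
- compound 1 `CNC(=O)/C=C/CN1CC(Oc2ccc(Oc3c(-c4ccc(F)cc4)sc4cc(O)ccc34)cc2)C1`: > 25000 nM
- compound 2 `C=CC(=O)NCCOc1ccc(Oc2c(-c3ccc(F)cc3)sc3cc(O)ccc23)cc1`: 23000 nM
- compound 3 `CN(C)C(=O)/C=C/CN1CC(Oc2ccc(Oc3c(-c4ccc(F)cc4)sc4cc(O)ccc34)cc2)C1`: 22300 nM

Compound 1 stands only at a limit of this assay, > 25000 nM, so no number is known for it; (the limit of > 25000 nM in this assay, at which 1 of the 3 values shown sits). Compound 2 and compound 3 sit close to that limit with their own numbers. The measured steps are all small: an at least 1.0-fold lower number from compound 1 to compound 2 (0.03 log units; that floor lies within the scatter), an at least 1.1-fold lower number from compound 1 to compound 3 (0.04 log units; that floor lies within the scatter) and a 1.0-fold lower number from compound 2 to compound 3 (0.01 log units; within the scatter), each within the scatter, so none of the three shown changes moved this assay beyond noise.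

Compound 4 `C=C(C)C(=O)N1CC(Oc2ccc(Oc3c(-c4ccc(F)cc4)sc4cc(O)ccc34)cc2)C1` differs from compound 1 by (1-methylethenyl)carbonyl in place of 3-(methylcarbamoyl)prop-2-en-1-yl on an amine nitrogen in a ring. Going by the values given here, no measured step touches the amine nitrogen in a ring in this way; the only nearby change, the methyl on the amide-type nitrogen from compound 1 to compound 3, stayed within the scatter. With every shown value near the limit, the step is expected to be none beyond the scatter, and a limit remains plausible for compound 4. Compound 4 is estimated at 25000 nM, between 10000 nM and 60000 nM. That estimate corresponds to the expected step of a number no higher from compound 1 to compound 4 (the limit leaves the size open).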

Compound 4, half-maximal inhibitory concentration: > 25000 nM
Compound 4 gave a limit, no number; the forecaster's own chance of this, stated with the estimate: 45%; the middle value lies on the limit itself.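

In this assay, the amine nitrogen in a ring now carries (1-methylethenyl)carbonyl, with 0 hydrogen-bond donors and 5 heavy atoms, in place of a side chain with 1 donor and 7 heavy atoms, and compound 4 still gives only a limit, not a number: the limit of > 25000 nM in this assay, at which 2 of the 4 values shown sit.

Against the two compounds with numbers, the readings are an at least 1.1-fold higher number from compound 3 to compound 4 (0.04 log units; that floor lies within the scatter) and an at least 1.0-fold higher number from compound 2 to compound 4 (0.03 log units; that floor lies within the scatter), so neither comparison separates compound 4 from them. The step between compound 1 and compound 4 cannot be read, as both stand at a limit.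

From the compounds shown here alone, whether any group on this nitrogen can bring the series clear of the limit remains open. The compounds shown say nothing about how a chain ending in a dimethylamine or a carboxylic acid would read at this place.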